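The source may report more compounds than this note shows. Statements on the series, on what has been measured and on what is new or still open speak of the compounds shown alone.

Of the compounds shown here, three built on the same core have been measured so far. Compound 1 is `CCCSc1nc(N/N=C/c2ccc(Cl)cc2)c2nnn(Cc3ccccc3)c2n1`. In a functional assay on ECa-109 cells (Homo sapiens) for antiproliferative activity, read by MTT assay, with a stated time of 72 h (a lower number here means a stronger inhibitor, a higher number a weaker inhibitor), compound 1 reaches only the limit of the assay, > 64000 nM. Compound 2 is `CCCSc1nc(N/N=C/c2ccc(Br)cc2)c2nnn(Cc3ccccc3)c2n1`. In this assay compound 2 also sits at the limit, giving > 64000 nM. Compound 3 is `CCCSc1nc(N/N=C/c2ccccc2)c2nnn(Cc3ccccc3)c2n1`. In this assay compound 3 likewise returns a limit rather than a number, > 64000 nM.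

Because all three results sit at the limit of > 64000 nM in this assay, at which 3 of the 3 values shown sit, the steps between them cannot be read: the change from chloro to bromo is a step that the two limits leave unreadable from compound 1 to compound 2, the change from chloro to hydrogen is a step that the two limits leave unreadable from compound 1 to compound 3, and the change from bromo to hydrogen is a step that the two limits leave unreadable from compound 2 to compound 3. Compound 3 therefore stands at the limit, with no readable step to either neighbour.

Compound 4 is `CCCSc1nc(N/N=C/c2ccc3ccccc3c2)c2nnn(Cc3ccccc3)c2n1`. It differs from compound 3 by naphthalen-2-yl in place of phenyl on a carbon with a double bond to nitrogen. Within the data shown here, none of the measured steps bears readably on this change, so nothing in the data points to a step in this assay in either direction beyond the scatter. Compound 4 is expected to give 64000 nM, estimated to lie between 20000 nM and 200000 nM. The step this estimate implies, a number no higher from compound 3 to compound 4 (the limit leaves the size open), is expected to be essentially none, and a further limit is the most likely outcome.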

Compound 4, half-maximal inhibitory concentration: > 64000 nM
Compound 4: no number, only a limit; the forecaster's own chance of this, stated with the estimate: 70%; the middle value lies on the limit itself.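

In this assay compound 4 also returns only a limit, > 64000 nM. The steps from compound 1, compound 2 and compound 3 to compound 4 therefore cannot be read, because of where all the values sit: the limit of > 64000 nM in this assay, at which 4 of the 4 values shown sit. The compounds shown leave open whether any change to this shared core would give a number rather than a limit in this assay.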